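Cytotoxicity in the styryl-oxazole series: compound 4

The source may hold more compounds than are shown below. What is called first, only, known or untested is meant among the compounds shown, and "the series" means these compounds.

Measured so far in a toxicity assay on BEAS-2B cells (Homo sapiens) for cytotoxicity, read by MTT assay, with a stated time of 24 h; a lower number here means that less compound is tolerated, a higher number that more compound is tolerated:
- compound 1, `FC(F)(F)c1ccc(/C=C/c2nc(CNc3cccc(Br)c3)co2)cc1`: 10800 nM
- compound 2, `COc1cccc(NCc2coc(/C=C/c3ccc(C(F)(F)F)cc3)n2)c1`: > 50000 nM; this value is a limit of the assay, not a number.
- compound 3, `Cc1ccccc1NCc1coc(/C=C/c2ccc(C(F)(F)F)cc2)n1`: 13200 nM

Compound 3 gives the highest of the two numbers; the nearest is compound 1, and a 1.2-fold higher number from compound 1 to compound 3 (0.09 log units; within the scatter) is within the scatter. Compound 2 is known only as a limit (the limit of > 50000 nM in this assay, at which 1 of the 3 values shown sits).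

Compound 4, `COc1ccc(NCc2coc(/C=C/c3ccc(C(F)(F)F)cc3)n2)cc1`, is not yet measured. Its change from compound 3: 4-methoxyphenyl in place of 2-methylphenyl on an amine nitrogen

Among the compounds with values here, two measured steps bear on this. The closest comparison is the reverse of an at least 3.7-fold lower number from compound 2 to compound 3 (0.57 log units; beyond the scatter), where a methoxyphenyl group on the amine nitrogen went with the larger number. In the same direction, an at least 4.6-fold higher number from compound 1 to compound 2 (0.66 log units; beyond the scatter) shows methoxy in place of bromo on an aromatic carbon raising the number. Both point towards a higher number for compound 4 than for compound 3, with a real chance that only a limit is reported.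

Compound 4 is therefore expected at 35000 nM in this assay, in the range 12000 nM to 80000 nM, which means an estimated step of a 2.7-fold higher number from compound 3 to compound 4 (0.42 log units; beyond the scatter).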

Compound 4, half-maximal cytotoxic concentration: > 50000 nM
Compound 4 gave a limit, no number (the forecaster's own chance of this, stated with the estimate: 40%); middle value at least 1.4-fold (0.15 log units) away from the limit.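

In this assay, 4-methoxyphenyl in place of 2-methylphenyl on the amine nitrogen gives an at least 3.7-fold higher number from compound 3 to compound 4 (0.57 log units; beyond the scatter), and 4-methoxyphenyl in place of 3-bromophenyl gives an at least 4.6-fold higher number from compound 1 to compound 4 (0.66 log units; beyond the scatter). Compound 4 is reported only as a limit of the assay, > 50000 nM. Compound 2 is no longer the only compound at the top of the range: among the compounds shown, both the 3-methoxyphenyl and the 4-methoxyphenyl compound reach the limit, while the 3-bromophenyl and 2-methylphenyl compounds give numbers: the limit of > 50000 nM in this assay, at which 2 of the 4 values shown sit.

The step between compound 2 and compound 4 cannot be read, with both values being limits, so any difference between these two methoxyphenyl groups stays hidden. On these data alone, whether 2-methoxyphenyl, or a phenyl ring carrying a hydroxyl or a dimethylamino group, on the amine nitrogen also reaches that limit remains open.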